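The source may report more compounds than this note shows. Statements on the series, on what has been measured and on what is new or still open speak of the compounds shown alone.

For the measured compounds named here, compound 1, `CC1=C(C(=O)OC(C)(C)C)C(c2cccs2)NC(=O)N1`, gives 26% in an assay on membranes from CHO cells for displacement of a labelled ligand from adenosine receptor A1 (Homo sapiens), read by scintillation counting, with a stated time of 60 min, tested at 1 uM (on this read-out higher numbers stand for more inhibition at the one concentration tested (going by the name of the read-out) and lower numbers for less inhibition), the highest of the three numbers measured so far. Compound 2, `CC1=C(C(=O)OC(C)(C)C)C(c2ccsc2)NC(=O)N1`, gives 15% in this assay; the step of a number 11 percentage points lower from compound 1 to compound 2 (beyond the scatter) lies beyond the scatter. Compound 3, `CC1=C(C(=O)OC(C)(C)C)C(c2cccs2)NC(=O)N1C`, gives 18%; the step of a number 8 percentage points lower from compound 1 to compound 3 (within the scatter) stays within the scatter. Compound 4, `CCCC(=O)C1=C(C)NC(=O)NC1c1cccs1`, differs from compound 1 by propyl in place of tert-butoxy on a carbonyl carbon. Neither measured step concerns the carbonyl carbon: one replaces the ring on the saturated ring carbon, the other adds methyl on the amide-type nitrogen, so neither bears on this change. Without a guide among the measured compounds, the expected step of a number 1 percentage points lower from compound 1 to compound 4 (within the scatter) is none beyond the scatter, though with wide uncertainty. Compound 4 is therefore estimated at 25%, with a range from 5% to 50%.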

Compound 4, a percentage reported as inhibition, at one concentration (the size of the read-out at that concentration, not a potency): 2%
The estimate for compound 4 lay 23 percentage points above the measured number, outside the stated range (below it).
By their numbers in this assay, from the lowest: compound 4; then compounds 2, 3 and 1 (each within the scatter of the next, the first and the last beyond it).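

On the carbonyl carbon, propyl in place of tert-butoxy gives a number 24 percentage points lower from compound 1 to compound 4 (beyond the scatter) in this assay. This shows that the read-out depends on the group at this position, and this step is larger than either of the two earlier steps from compound 1. Nothing shown here accounts for the step.

The compounds shown leave open whether the step follows the loss of the oxygen of tert-butoxy or the change in the carbon group. Ethoxy or tert-butyl on the same carbonyl carbon would help separate the two.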